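The source may report more compounds than this note shows. Statements on the series, on what has been measured and on what is new or still open speak of the compounds shown alone.

Measured so far:
compound 1 `Cc1ccnc(N2C(=O)CS[C@H]2c2cccc(C(=O)NCCCCn3cccn3)c2)c1` — > 10000 nM (a limit, not a number)
compound 2 `O=C(NCCCCc1ccccc1)c1cccc(C2OCC(=O)N2c2cccc(F)c2)c1` — 320 nM
compound 3 `COc1cc(F)ccc1N1C(=O)CSC1c1cccc(C(=O)NCCCCc2ccccc2)c1` — 71.1 nM

All three were tested in a functional assay on HOS-TE85 cells (Homo sapiens) for inhibition, read by CCK-8 assay, with a stated time of 72 h; a higher number here means a weaker inhibitor, a lower number a stronger inhibitor. In this assay compound 1 gives only > 10000 nM, which is a limit of the assay rather than a number. Compound 1 thus stands at the limit of > 10000 nM in this assay, at which 1 of the 3 values shown sits, and of the three compounds it alone sits there. Compound 2 gives 320 nM in this assay, and compound 3 gives 71.1 nM; both of these are numbers well inside the measured range, so the two of them show what compounds of this shape can reach.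

Compound 4 `Cc1ccnc(N2C(=O)CS[C@@H]2c2cccc(C(=O)NCCCCn3cccn3)c2)c1` has not yet been measured. It differs from compound 1 in one place: the two compounds have the same atoms and bonds and differ only in configuration as drawn: 1 of 1 stereo elements differ; a stereocentre at a saturated ring carbon is drawn S in compound 1 and R in compound 4.

Among the compounds with values here, no step between two measured compounds that differ in one place is available here, so the size of the change cannot be read off another pair. Because compound 1 stands at the limit of > 10000 nM in this assay, at which 1 of the 3 values shown sits, only a move toward stronger inhibition could be seen at all; a move the other way would stay hidden at the limit. The expectation is therefore for a step toward stronger inhibition, though with wide uncertainty and a real chance that only a limit is reported again. The step this estimate implies is an at least 3.3-fold lower number from compound 1 to compound 4 (0.52 log units; beyond the scatter). Compound 4 is estimated at 3000 nM, with a range from 300 nM to 30000 nM.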

Compound 4, half-maximal inhibitory concentration: 21.9 nM
Compound 4: middle estimate off by 140-fold (2.14 log units), on the high side, and the stated range ends above it.
By their numbers in this assay, from the lowest: compound 4; then compound 3; then compound 2. At a limit, above all of these: compound 1.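

Inverting the stereocentre at the saturated ring carbon, drawn S in compound 1 and R in compound 4, gives in this assay an at least 450-fold lower number from compound 1 to compound 4 (2.65 log units; beyond the scatter). Within the data shown here, nothing enters or leaves in this step, so this one stereocentre is the only structural change behind the gap, something the earlier compounds could not show, since no two of them formed a pair differing in one place: the fact that compounds 1 and 4 differ only in the configuration as drawn. For compound 1 the value > 10000 nM is a limit and not a number: the limit of > 10000 nM in this assay, at which 1 of the 4 values shown sits.

Compound 2 and compound 3 are drawn without a configuration at this carbon and differ from compound 4 in more than one place, so the compounds shown do not tell whether the same configuration would matter as much in their series. Also open, on these data alone, is whether compound 4 would keep its strength in this assay with a carboxylic acid or an amine as the end group of the amide side chain, and whether the S form would stay at the limit with such a group.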